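A Basic Side Chain Added to the Core of Compound 1

The compounds below may be only part of what the source reports. "The series", "measured", "known", "first", "only" and "open" are said of these compounds alone.

Compound 1 `Cc1nc2ccccc2c(-c2ccccc2)c1C(=O)N(C)c1ccccc1`: > 10000 nM
Compound 2 `CCN(CC)C(=O)c1cc(-c2ccccc2)c2ccccc2c1`: 5 nM
Compound 3 `CCN(Cc1ccccc1)Cc1nc2ccccc2c(-c2ccccc2)c1C(=O)NCc1ccccc1`: 2900 nM

All three were tested in an assay on brain with Translocator protein (Rattus norvegicus) as the target; on this read-out lower numbers stand for stronger inhibition and higher numbers for weaker inhibition. For compound 1 the reading is a limit of the assay, not a number (the limit of > 10000 nM in this assay, at which 1 of the 3 values shown sits). Compound 2 and compound 3 each give a number, and the two numbers differ beyond the usual scatter.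

Compound 4 `CCN(Cc1ccccc1)Cc1nc2ccccc2c(-c2ccccc2)c1C(=O)N(C)c1ccccc1` differs from compound 1 by benzyl(ethyl)amino in place of hydrogen on a saturated chain carbon bound to an aromatic carbon. Going by the values given here, no measured pair shows this change alone; compound 3 carries the same group together with a different amide and gives 2900 nM. On that basis a gain is expected from compound 1 to compound 4 in this assay, of roughly an at least 2.0-fold lower number from compound 1 to compound 4 (0.30 log units; that floor lies within the scatter). Compound 4 is therefore estimated at 5000 nM, within 1500 nM to 20000 nM.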

Compound 4, half-maximal inhibitory concentration: 1320 nM
Compound 4: middle estimate off by 3.8-fold (0.58 log units), on the high side; measured number outside the range, below it.
By their numbers in this assay, from the lowest: compound 2; then compound 4; then compound 3. At a limit, above all of these: compound 1.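

In this assay benzyl(ethyl)amino on a saturated chain carbon bound to an aromatic carbon brings an at least 7.5-fold lower number from compound 1 to compound 4 (0.87 log units; beyond the scatter) and so gives a measured number on the core of compound 1. For compound 1 the reading of > 10000 nM is a limit of the assay, so that step has only a floor. With this group in place, methyl(phenyl)amino in place of benzylamino on a carbonyl carbon brings a 2.2-fold lower number from compound 3 to compound 4 (0.34 log units; beyond the scatter) and shows that the amide also moves the number.

As far as these compounds go, whether dimethylamino or morpholine on this chain carbon would do the same remains open. So does the separate share of the benzyl and the ethyl on the amine.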